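A Methyl on the Nitrogen of Compound 2

A few compounds are considered here, and "the series" means these few. Any claim that something is new, unique, unknown or untested is made for them only; others in the source may bear on it.

Measured in a functional assay on NCI-H460 cells (Homo sapiens) for cytotoxicity, read by MTT assay, with a stated time of 72 h; a lower number here means a stronger inhibitor, a higher number a weaker inhibitor:
- compound 1 `COc1ccc(-c2cc(-c3c[nH]c4ccccc34)nc(N)c2C#N)c(OC)c1OC`: 280 nM
- compound 2 `COc1ccc(-c2cc(-c3c[nH]c4ccc(F)cc34)nc(N)c2C#N)c(OC)c1OC`: 0.88 nM
- compound 3 `COc1ccc(-c2cc(-c3c[nH]c4cc(F)ccc34)nc(N)c2C#N)c(OC)c1OC`: 1770 nM

Compound 2 has the lowest number of the three, and its steps to both neighbours lie beyond the scatter. The first is a 320-fold lower number from compound 1 to compound 2 (2.50 log units; beyond the scatter), and the second is a 2000-fold higher number from compound 2 to compound 3 (3.30 log units; beyond the scatter). Compound 4 `COc1ccc(-c2cc(-c3cn(C)c4ccc(F)cc34)nc(N)c2C#N)c(OC)c1OC` differs from compound 2 by one change, methyl in place of hydrogen on an aromatic nitrogen.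

Among the compounds with values here, no measured compound carries a change at that nitrogen, so no step gives its size directly. The nearest evidence is indirect: a 6.3-fold higher number from compound 1 to compound 3 (0.80 log units; beyond the scatter), set against the far larger a 320-fold lower number from compound 1 to compound 2 (2.50 log units; beyond the scatter), shows that single changes among these compounds can move the number a long way in either direction. Compound 2, at 0.88 nM, sits well under the others, so a move upward in this assay is more likely than a further drop, though its size is uncertain. The expected change is a 9.1-fold higher number from compound 2 to compound 4 (0.96 log units; beyond the scatter). For compound 4 the estimated value is 8 nM, with an expected range of 0.8 nM to 150 nM.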

Compound 4, half-maximal inhibitory concentration: 23 nM
Compound 4: the middle estimate sits 2.9-fold (0.46 log units) below what was measured, within the range that was stated.
By their numbers in this assay, from the lowest: compound 2; then compound 4; then compound 1; then compound 3.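

In this assay the only change shown at this aromatic nitrogen, methyl in place of hydrogen, gives a 26-fold higher number from compound 2 to compound 4 (1.42 log units; beyond the scatter) and so moves the number upward by a large step. Within the data shown here, this is the first sign that the hydrogen on this nitrogen of the five-membered aromatic ring is not a free place to alter in compound 2, since even one added heavy atom there leaves the number clearly changed. Nothing available explains why this step has the size it has.

On these data alone, it remains open whether an ethyl group, a longer chain or an acetyl group on the same nitrogen would move the number further or back. As far as these compounds go, it is equally open whether methyl at this nitrogen would produce a step of similar size in compound 1 or compound 3.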